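Alkyltriazene series: shortening the chain on the triazene nitrogen

The compounds below may be only part of what the source reports. "The series", "measured", "known", "first", "only" and "open" are said of these compounds alone.

Measured so far:
compound 1 `CCN(C)/N=N/c1ccc(NC(N)=O)cc1`: 3.87
compound 2 `CCCCN(C)/N=N/c1ccc(C(N)=O)cc1`: 3.47

In a functional assay on L1210 cells (Mus musculus) for antiproliferative activity (on this read-out higher numbers stand for higher potency (the scale is a negative logarithm) and lower numbers for lower potency), compound 2 gives 3.47, the lower of the two numbers; compound 1 sits higher by more than the scatter. Compound 3 `CCN(C)/N=N/c1ccc(C(N)=O)cc1` has not been measured. It differs from compound 2 by hydrogen in place of ethyl on a saturated chain carbon, two bonds along the chain from an amine nitrogen. For the measured compounds named here, no step between measured compounds isolates this change, so the expectation rests on the two values alone. The step of a number 0.13 log units higher from compound 2 to compound 3 (within the scatter) is my own estimate, and this estimated step is expected to be small, within the scatter or barely beyond it, with no firm direction. Compound 3 is estimated at 3.6, between 3.1 and 4.1.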

Compound 3, logarithm of the reciprocal of the active concentration, log(1/C): 3.66
Estimate against measurement, compound 3: 0.06 log units below, and the stated range covers the measured number.
By their numbers in this assay, from the lowest: compounds 2, 3 and 1 (each within the scatter of the next, the first and the last beyond it).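

In this assay cutting butyl to ethyl gives a number 0.19 log units higher from compound 2 to compound 3 (within the scatter) and so does not separate these two chains at this place. Carbamoyl in place of ureido on an aromatic carbon gives a number 0.21 log units lower from compound 1 to compound 3 (within the scatter) and leaves that exchange unresolved as well. Nothing available bears on the reason for either result.

Still open, as far as these compounds go, is whether a longer chain such as hexyl, or a bare hydrogen on the amine nitrogen in place of the chain, would move the number beyond the scatter. A carboxylic acid or an amine on the aromatic carbon also remains untested in the compounds shown.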